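Swapping a Hydroxypropyl Chain for an Aryl-Bearing Arm

The source may report more compounds than this note shows. Statements on the series, on what has been measured and on what is new or still open speak of the compounds shown alone.

Of the compounds shown here, three sharing one core have been tested in a toxicity assay on MDCK cells (Canis lupus familiaris) for cytotoxicity, read by crystal violet staining, with a stated time of 48 h; a lower number here means that less compound is tolerated, a higher number that more compound is tolerated. Compound 1, `Cc1ccc2cc(CN(Cc3ccc(C(C)C)cc3)Cc3cccc(F)c3)c(=O)[nH]c2c1`, gives > 33000 nM, which is a limit of the assay and not a number. Compound 2, `Cc1ccc2[nH]c(=O)c(CN(CCCO)Cc3ccc(C(C)(C)C)cc3)cc2c1`, likewise gives only a limit, > 10000 nM. Compound 3, `CCc1ccc2[nH]c(=O)c(CN(CCCO)Cc3ccc(C(C)(C)C)cc3)cc2c1`, also gives only a limit, > 10000 nM. Compound 3 therefore stands with every other value shown: none of the three compounds shows a measurable number, only limits. Among the measured compounds shown here, the single step between compounds that differ in one place, a step that the two limits leave unreadable from compound 2 to compound 3, cannot be read, and the two observations the limit of > 10000 nM in this assay, at which 2 of the 3 values shown sit, and the limit of > 33000 nM in this assay, at which 1 of the 3 values shown sits, merely record where the limits sit.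

Compound 4, `CCc1ccc2[nH]c(=O)c(CN(Cc3ccc(C(C)(C)C)cc3)C(C)c3ccc(OC(F)F)cc3)cc2c1`, differs from compound 3 by 1-(4-(difluoromethoxy)phenyl)ethyl in place of 3-hydroxypropyl on an amine nitrogen. For the measured compounds named here, no measured step bears on such an exchange; the step from compound 2 to compound 3 concerns a different position and is itself unreadable. The expectation therefore rests only on the fact that all three measured compounds sit at limits, and is that compound 4 is tolerated up to a broadly similar level, while allowing for the chance that a measurable value appears. The step expected is a step that the limit leaves unreadable from compound 3 to compound 4. Compound 4 is estimated at 15000 nM, with a range from 4000 nM to 50000 nM.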

Compound 4, half-maximal cytotoxic concentration: > 5000 nM
Compound 4: no number, only a limit (the forecaster's own chance of this, stated with the estimate: 55%); the middle value lies beyond the limit too.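

Compound 4 gives > 5000 nM, which is a limit of the assay and not a number. Compound 3 also has only a limit, so the step from compound 3 to compound 4 cannot be read. The compounds shown leave open at what concentration any of the four harms the cells, and whether exchanging 3-hydroxypropyl for 1-(4-(difluoromethoxy)phenyl)ethyl alters that concentration.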